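Methylpiperidine in place of piperidine on an inactive scaffold

A few compounds are considered here, and "the series" means these few. Any claim that something is new, unique, unknown or untested is made for them only; others in the source may bear on it.

Compound 1 `CC1CCN(c2ccc(Nc3ncc4c(n3)N(C3CCCC3)CC(=O)N4C)cc2)CC1`: > 30000 nM, a limit of the assay
Compound 2 `CCN1C(=O)CN(C2CCCC2)c2nc(Nc3ccc(N4CCN(C)CC4)cc3)ncc21`: 28300 nM
Compound 3 `CCN1C(=O)CN(C2CCCC2)c2nc(Nc3ccc(N4CCCCC4)cc3)ncc21`: > 30000 nM, a limit of the assay

In a functional assay on HeLa cells (Homo sapiens) for inhibition, read by MTT assay, with a stated time of 48 h (on this read-out higher numbers stand for weaker inhibition and lower numbers for stronger inhibition), compound 3 gives > 30000 nM, which is a limit of the assay and not a number. Two of the three values shown sit at that limit (the limit of > 30000 nM in this assay, at which 2 of the 3 values shown sit). Going by the values given here, the only measured step that reaches compound 3 is an at least 1.0-fold higher number from compound 2 to compound 3 (0.02 log units; that floor lies within the scatter), a change that stays within the scatter and ends at the limit.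

Compound 4 `CCN1C(=O)CN(C2CCCC2)c2nc(Nc3ccc(N4CCC(C)CC4)cc3)ncc21` differs from compound 3 by methyl in place of hydrogen on a saturated ring carbon; cut one bond further out, the same change reads piperidin-1-yl to 4-methylpiperidin-1-yl. Compound 1, which carries that 4-methylpiperidin-1-yl group on a core with a methyl rather than an ethyl on the lactam nitrogen, also sits at the limit in this assay. Among the compounds with values here, no measured step shows a methyl on that ring moving the read-out, so no step beyond the scatter is expected for a number no higher from compound 3 to compound 4 (the limit leaves the size open). Compound 4 is therefore estimated at 30000 nM, with a range from 15000 nM to 60000 nM, most likely reported again as a limit.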

Compound 4, half-maximal inhibitory concentration: > 30000 nM
Compound 4 gave a limit, no number (the forecaster's own chance of this, stated with the estimate: 75%); the middle value sits exactly at the limit.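

In this assay compound 4 gives > 30000 nM, a limit of the assay and not a number. Going by these compounds alone, the steps to compound 4 from compound 3 and from compound 1 cannot be read, so the methyl on this saturated ring carbon has no size that can be stated, and with 4-methylpiperidin-1-yl the ethyl-bearing core ends at the same limit as the core of compound 1: the limit of > 30000 nM in this assay, at which 3 of the 4 values shown sit. The one readable step, 4-methylpiperidin-1-yl in place of 4-methylpiperazin-1-yl on an aromatic carbon, is an at least 1.0-fold higher number from compound 2 to compound 4 (0.02 log units; that floor lies within the scatter), the same picture that the piperidin-1-yl change gave.

The compounds shown leave open whether a hydroxyl, a primary amine or a carboxylic acid on this ring carbon would give a number rather than a limit. They also leave open the size and the direction of the methyl change itself.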